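The source may hold more compounds than are shown below. What is called first, only, known or untested is meant among the compounds shown, and "the series" means these compounds.

Compound 1, `CCCC(=O)Oc1ccc2oc(/C=C/[S+](C)[O-])cc(=O)c2c1`: 2200 nM
Compound 2, `COc1cccc2c(=O)cc(/C=C/[S+](C)[O-])oc12`: 2200 nM

In a functional assay on A549 cells (Homo sapiens) for cytotoxicity, with a stated time of 48 h (a higher number here means a weaker inhibitor, a lower number a stronger inhibitor), compound 1 gives 2200 nM and stands level with compound 2, which gives 2200 nM; the two do not differ beyond the usual scatter. Compound 3, `CC(C)C(=O)Oc1ccc2oc(/C=C/[S+](C)[O-])cc(=O)c2c1`, has not been measured yet. It differs from compound 1 by isopropyl in place of propyl on a carbonyl carbon. Among the measured compounds shown here, no pair of measured compounds shows this kind of change, so there is nothing to point to a shift in either direction. The step of no change at the digits printed from compound 1 to compound 3 (within the scatter) is therefore expected to stay within the scatter. Compound 3 is expected to give about 2200 nM, with a range from 1100 nM to 4400 nM.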

Compound 3, half-maximal inhibitory concentration: 2400 nM
The estimate for compound 3 lay 1.1-fold (0.04 log units) below the measured number; the measured number falls inside the stated range.
By their numbers in this assay, from the lowest: compounds 1, 2 and 3 (each within the scatter of the next).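

In this assay, isopropyl in place of propyl on a carbonyl carbon gives a 1.1-fold higher number from compound 1 to compound 3 (0.04 log units; within the scatter) and so stays within the scatter. This is the first change shown at this position, and it indicates that rearranging these three carbons into a branched chain does not separate the two compounds in this assay. Nothing available here offers an explanation for this result. Still open, as far as these compounds go, is whether a longer chain such as hexyl, a phenyl ring or an amine on the same carbonyl carbon would move the number. One swap between two chains of equal size cannot show how far this position tolerates change.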